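Benzyl to 2-methoxyphenyl on the amide of compound 1

The source may hold more compounds than are shown below. What is called first, only, known or untested is meant among the compounds shown, and "the series" means these compounds.

In an ADME assay on SH-SY5Y cells (Homo sapiens) for cytotoxicity, read by MTT assay, with a stated time of 48 h (a higher number here means a weaker inhibitor, a lower number a stronger inhibitor), compound 1 (`COc1ccc(C(=O)/C=C/c2ccc(C(=O)NCc3ccccc3)cc2)c(O)c1`) gives > 100000 nM and this figure is a limit, not a number. Compound 2 (`COc1ccc(C(=O)/C=C/c2cc(OC)c(OC)cc2OC)c(O)c1`) gives > 100000 nM and this too is a limit. Compound 3 (`COc1ccc(C(=O)/C=C/c2cc(Br)c(OCc3ccccc3)c(OC)c2)c(O)c1`) gives > 100000 nM and this is likewise a limit. Compound 1 therefore has no numeric place in the series and shares its position with the other two: the limit of > 100000 nM in this assay, at which 3 of the 3 values shown sit, is all that the readings show. No two of these compounds differ in one place only, so no measured step is available for sizing a change.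

Compound 4 (`COc1ccc(C(=O)/C=C/c2ccc(C(=O)Nc3ccccc3OC)cc2)c(O)c1`) has 2-methoxyphenyl in place of benzyl on an amide-type nitrogen and keeps the rest of the core of compound 1. Among the compounds with values here, since compound 1 gives > 100000 nM as a limit and no compound gives a number, no step beyond the scatter is expected in this assay in either direction. The estimated change is a number no higher from compound 1 to compound 4 (the limit leaves the size open) and it is expected to remain within the scatter. For compound 4 the estimated value is 100000 nM with an expected range of 40000 nM to 250000 nM and a reading that is again only a limit is the likeliest outcome.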

Compound 4, half-maximal inhibitory concentration: > 100000 nM
Compound 4: a limit, no number; the forecaster's own chance of this, stated with the estimate: 80%; the middle value sits exactly at the limit.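

Compound 1 and compound 4 both read only as limits, so no step can be read between them for 2-methoxyphenyl in place of benzyl on the amide-type nitrogen. The compounds shown leave open what numeric value any of them would give in this assay: the limit of > 100000 nM in this assay, at which 4 of the 4 values shown sit.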